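Methylsulfonyl for trifluoromethyl on compound 1

A few compounds are considered here, and "the series" means these few. Any claim that something is new, unique, unknown or untested is made for them only; others in the source may bear on it.

For the measured compounds named here, compound 1 `FC(F)(F)c1ccc(Nc2ncnc3sc(Nc4c(Cl)cccc4Cl)nc23)cc1` gives 12 nM in a functional assay on HEK293 cells for antagonist activity at transient receptor potential cation channel subfamily V member 1 (Homo sapiens), read by calcium flux (a higher number here means a weaker inhibitor, a lower number a stronger inhibitor), the lowest of the three numbers measured so far. Compound 2 `FC(F)(F)c1ccc(Nc2ncnc3sc(Nc4ccccc4Cl)nc23)cc1` gives 64 nM and compound 3 `FC(F)(F)c1ccc(Nc2ncnc3sc(Nc4ccccc4C(F)(F)F)nc23)cc1` gives 74 nM; the steps of a 5.3-fold higher number from compound 1 to compound 2 (0.73 log units; beyond the scatter) and a 6.2-fold higher number from compound 1 to compound 3 (0.79 log units; beyond the scatter) both lie beyond the scatter, whereas a 1.2-fold higher number from compound 2 to compound 3 (0.06 log units; within the scatter) does not. Compound 4 `CS(=O)(=O)c1ccc(Nc2ncnc3sc(Nc4c(Cl)cccc4Cl)nc23)cc1` differs from compound 1 by methylsulfonyl in place of trifluoromethyl on an aromatic carbon. All three measured steps concern the group on the nitrogen on an aromatic ring, so none of them bears on this change, and no direction can be read from them. The expectation for compound 4 in this assay is therefore a step of a 2.5-fold higher number from compound 1 to compound 4 (0.40 log units; beyond the scatter), with a wide range to reflect the absence of a comparable step. Compound 4 is estimated at 30 nM, between 6 nM and 150 nM.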

Compound 4, half-maximal inhibitory concentration: 5 nM
The estimate for compound 4 lay 6.0-fold (0.78 log units) above the measured number; the measured number lies below the stated range.
By their numbers in this assay, from the lowest: compound 4; then compound 1; then compounds 2 and 3 (each within the scatter of the next).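

For the compounds shown here, the only step at this position, methylsulfonyl in place of trifluoromethyl on an aromatic carbon para to a large group, is a 2.4-fold lower number from compound 1 to compound 4 (0.38 log units; beyond the scatter) in this assay. The position therefore accepts a group counted with two hydrogen-bond acceptors in place of one with none, and the number falls. Nothing measured here accounts for this step.

As far as these compounds go, whether an amine, a carboxylic acid or ethylsulfonyl at this position would give a similar number remains open. So does whether methylsulfonyl gives a like step on compound 2 or compound 3.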